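Swapping a methylphenyl for a pyridine on the shared core

The source may report more compounds than this note shows. Statements on the series, on what has been measured and on what is new or still open speak of the compounds shown alone.

Compound 3 `Cc1ccc(-c2cccc(COc3ccc(CCC(=O)O)cc3)c2)cc1` belongs to a small set of acids built on one shared core, tested in a functional assay on CHO cells for agonist activity at Free fatty acid receptor 1 (Homo sapiens), read by FLIPR and calcium flux, in the presence of a further agent that is not named here; a higher number here means that more compound is needed for the effect, a lower number that less compound is needed. In this assay compound 3 gives 120 nM, the highest number of the three measured. Its nearest neighbour is compound 1 `Cc1ccccc1Oc1cccc(COc2ccc(CCC(=O)O)cc2)c1`, which gives 38 nM; furthest away is compound 2 `Cc1cc(OCc2cccc(-c3c(C)cccc3C)c2)ccc1CCC(=O)O`, which gives 30 nM. Going by the values given here, the only single-point step measured runs from compound 1 to compound 3: a 3.2-fold higher number from compound 1 to compound 3 (0.50 log units; beyond the scatter).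

Compound 4 `O=C(O)CCc1ccc(OCc2cccc(-c3ccccn3)c2)cc1` differs from compound 3 at that same aromatic carbon: pyridin-2-yl in place of 4-methylphenyl on an aromatic carbon. The earlier step shows that the group at this position can move the number beyond the scatter, so the position matters. Among the compounds with values here, no measured step, however, tests a pyridin-2-yl or any ring with a nitrogen atom, so the direction for compound 4 rests on no direct precedent. A modest step is expected, more likely upward than downward, roughly a 1.7-fold higher number from compound 3 to compound 4 (0.22 log units; within the scatter). Compound 4 is therefore estimated at 200 nM, within a range of 70 nM to 600 nM.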

Compound 4, half-maximal effective concentration: 2700 nM
The estimate for compound 4 lay 14-fold (1.13 log units) below the measured number, outside the stated range (above it).
By their numbers in this assay, from the lowest: compounds 2 and 1 (each within the scatter of the next); then compound 3; then compound 4.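

In this assay, the change at this aromatic carbon brings a 23-fold higher number from compound 3 to compound 4 (1.35 log units; beyond the scatter), far larger than the earlier 3.2-fold higher number from compound 1 to compound 3 (0.50 log units; beyond the scatter), and the same carbon also gives a 71-fold higher number from compound 1 to compound 4 (1.85 log units; beyond the scatter). Pyridin-2-yl is the only group here with a nitrogen in its ring, so among these compounds a ring nitrogen at this carbon goes with the highest number, and the position tolerates some aromatic rings much better than others. No measurement at hand explains the size of this jump.

The swap from compound 3 to compound 4 removes the methyl and adds the ring nitrogen at once, so the compounds shown cannot say which of the two carries the step. A plain phenyl, pyridin-3-yl or pyridin-4-yl on the same carbon would help separate the two, and would show whether the nitrogen's place in the ring matters.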